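The source may report more compounds than this note shows. Statements on the series, on what has been measured and on what is new or still open speak of the compounds shown alone.

Measured compounds:

compound 1, `O=C(/C=C/C=C/C=C/c1ccc[nH]1)c1ccccc1`: 9890 nM
compound 2, `O=C(/C=C/C=C/C=C/C=C/c1ccc[nH]1)c1ccccc1`: 5990 nM
compound 3, `O=C(/C=C/C=C/C=C/c1ccc[nH]1)OCc1ccccc1`: a limit of the assay, > 10000 nM

These three compounds were tested in a functional assay on Raji cells (Homo sapiens) for cytotoxicity, with a stated time of 72 h; on this read-out higher numbers stand for weaker inhibition and lower numbers for stronger inhibition. Compound 1 and compound 2 share a core; the pair differs only at the end of the unsaturated chain:

2-(1H-pyrrol-2-yl)ethenyl in place of 1H-pyrrol-2-yl on a double-bonded chain carbon bound to a double-bonded chain carbon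

This change gave a 1.7-fold lower number from compound 1 to compound 2 (0.22 log units; within the scatter). The two values therefore cannot be told apart with confidence.

Compound 3 has a different core from compound 1, and the difference between the two cores is not broken down here. In this assay compound 3 reached only the limit of the assay, so its value is not a number but a bound. The limit is the limit of > 10000 nM in this assay, at which 1 of the 3 values shown sits.

Compound 4, `O=C(/C=C/C=C/C=C/C=C/c1ccc[nH]1)OCc1ccccc1`, is not yet measured. It stands to compound 3 exactly as compound 2 stands to compound 1; the change is the same:

2-(1H-pyrrol-2-yl)ethenyl in place of 1H-pyrrol-2-yl on a double-bonded chain carbon bound to a double-bonded chain carbon

The step from compound 3 to compound 4 is expected to be about a step that the limit leaves unreadable from compound 3 to compound 4, a size that rests on the same change being made from compound 1 to compound 2, which gave a 1.7-fold lower number from compound 1 to compound 2 (0.22 log units; within the scatter) and stayed within the scatter. Because compound 3 itself sits at the limit of the assay, (the limit of > 10000 nM in this assay, at which 1 of the 3 values shown sits), compound 4 is expected to land near that limit as well. The estimate for compound 4 in this assay is 12000 nM, with a likely range from 5000 nM to 30000 nM.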

Compound 4, half-maximal inhibitory concentration: 1400 nM
Beside the measured number, compound 4's estimate is 8.6-fold (0.93 log units) above it; the whole stated range lies above it.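

In this assay, putting 2-(1H-pyrrol-2-yl)ethenyl in place of 1H-pyrrol-2-yl on the core of compound 3 gave an at least 7.1-fold lower number from compound 3 to compound 4 (0.85 log units; beyond the scatter), a real drop rather than scatter between repeated measurements. The same change therefore does not carry over with one fixed size in this series, since the step on the core of compound 1 and the step on the core of compound 3 differ: the same change on two cores in this assay, a 1.7-fold lower number (0.22 log units; within the scatter) from compound 1 to compound 2 and an at least 7.1-fold lower number (0.85 log units; beyond the scatter) from compound 3 to compound 4, at least 4.3-fold (0.63 log units) apart, beyond the scatter of two such steps

Compound 3 gives > 10000 nM, which is a limit of the assay and not a number, so the full size of its step stays unknown, and two cores alone show neither why the steps differ nor what the change would do on a third core.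

As far as these compounds go, how a still longer chain would read on either core remains open, and so does the question of whether the gap between the two steps would persist with it. Also open, from the compounds shown here alone, is what an amide in place of the ester of compound 4, or an amine or a carboxylic acid in place of the 1H-pyrrol-2-yl, would do in this assay.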